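The source may report more compounds than this note shows. Statements on the series, on what has been measured and on what is new or still open speak of the compounds shown alone.

Measured in a functional assay on HeLa cells (Homo sapiens) for cytotoxicity, read by MTT assay; on this read-out higher numbers stand for weaker inhibition and lower numbers for stronger inhibition:
- compound 1 `COC(=O)C[C@H]1C[C@H](O)[C@@H](C)[C@@H](c2ccc(OC)cc2)N1`: 5300 nM
- compound 2 `COc1ccc([C@H]2N[C@@H](CCO)C[C@H](O)[C@H]2C)cc1`: 16500 nM

Of these two, compound 2 has the higher number, 16500 nM, and so is the weaker inhibitor. Compound 3 `COc1ccc([C@H]2N[C@@H](CC(=O)O)C[C@H](O)[C@H]2C)cc1` differs from it in one place: carboxy in place of hydroxymethyl on a saturated chain carbon bound to a saturated ring carbon. Carboxy stands in place of hydroxymethyl on a saturated chain carbon bound to a saturated ring carbon. For the measured compounds named here, only one measured step bears on this place, a modest one: a 3.1-fold higher number from compound 1 to compound 2 (0.49 log units; beyond the scatter). It does not show how carboxy will behave, so no change beyond the scatter is expected in this assay. The expected step is a 1.1-fold lower number from compound 2 to compound 3 (0.04 log units; within the scatter). For compound 3 the estimated value is 15000 nM, with an expected range of 5000 nM to 50000 nM.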

Compound 3, half-maximal inhibitory concentration: 19900 nM
Compound 3: middle estimate off by 1.3-fold (0.12 log units), on the low side; measured number inside the range.
By their numbers in this assay, from the lowest: compound 1; then compounds 2 and 3 (each within the scatter of the next).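

In this assay, carboxy in place of hydroxymethyl gives a 1.2-fold higher number from compound 2 to compound 3 (0.08 log units; within the scatter) and so leaves the two groups indistinguishable at this place. Methoxycarbonyl now stands apart from both, since hydrogen in place of methyl on an oxygen next to a carbonyl group gives a 3.8-fold higher number from compound 1 to compound 3 (0.57 log units; beyond the scatter) in the same assay. Nothing measured here explains either step.

Going by these compounds, whether an amine or an amide at this place would behave like methoxycarbonyl or like carboxy remains open. So does whether an ethyl ester or a longer chain would keep the lower number of compound 1.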